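The source may hold more compounds than are shown below. What is called first, only, known or untested is meant among the compounds shown, and "the series" means these compounds.

In a functional assay on PC-3 cells (Homo sapiens) for cytotoxicity, read by WST assay, with a stated time of 24 h (a higher number here means a weaker inhibitor, a lower number a stronger inhibitor), three compounds have been measured so far. Compound 1 (`COc1ccc2c(/C=C(\C#N)C(=O)c3c[nH]c4cc(F)ccc34)c[nH]c2c1`) gives only a limit of > 50000 nM and no exact number. Compound 3 (`COc1ccc2[nH]cc(/C=C(\C#N)C(=O)c3c[nH]c4cc(F)ccc34)c2c1`) likewise gives only a limit of > 50000 nM and no exact number. Going by the values given here, compound 2 (`N#C/C(=C\c1cn(Cc2ccc(Cl)cc2)c2ccc(Br)cc12)C(=O)c1c[nH]c2ccccc12`), at 47100 nM, holds the only exact number, so there is little to compare it with. Compound 4 (`N#C/C(=C\c1cn(Cc2ccc(Cl)cc2)c2ccccc12)C(=O)c1c[nH]c2ccccc12`) is still unmeasured and has hydrogen in place of bromo on an aromatic carbon. Among the compounds with values here, no measured pair shows what this swap does, so, starting from compound 2 at 47100 nM, no change beyond the usual scatter is expected, in either direction. The expected step of a 1.0-fold lower number from compound 2 to compound 4 (0.02 log units; within the scatter) is therefore small. For compound 4 the estimate is 45000 nM with 15000 nM to 90000 nM as the expected range.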

Compound 4, half-maximal inhibitory concentration: > 50000 nM
Compound 4 was reported as a limit; the forecaster's own chance of this, stated with the estimate: 50%; middle value at least 1.1-fold (0.04 log units) away from the limit.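

Replacing bromo with hydrogen on this aromatic carbon gives, in this assay, an at least 1.0-fold higher number from compound 2 to compound 4 (0.02 log units; that floor lies within the scatter). Going by these compounds alone, this is the first look at the position, and it gives no sign that hydrogen makes a stronger inhibitor than bromo. How far the change really reaches stays unknown, since the result for compound 4 is a limit and not a number: the limit of > 50000 nM in this assay, at which 3 of the 4 values shown sit.

The compounds shown leave open how an amine or a carboxylic acid on this aromatic carbon would read. They also leave open whether any group here can give a number well clear of that limit.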